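Hydroxy to chloro on the aryl ketone ring

The source may hold more compounds than are shown below. What is called first, only, known or untested is meant among the compounds shown, and "the series" means these compounds.

For the measured compounds named here, compound 2 `O=C(/C=C/c1cc2ccccc2[nH]c1=O)c1ccc(O)cc1` sits at the low end of the two numbers measured so far, though the gap to its only neighbour is within the scatter: in a functional assay on BT-549 cells (Homo sapiens) for cytotoxicity, read by sulforhodamine B assay, with a stated time of 24 h (on this read-out higher numbers stand for weaker inhibition of growth and lower numbers for stronger inhibition of growth), compound 2 gives 1950 nM. Compound 1 `COc1ccc(C(=O)/C=C/c2cc3ccccc3[nH]c2=O)cc1` in this assay gives 2700 nM; the step of a 1.4-fold lower number from compound 1 to compound 2 (0.14 log units; within the scatter) does not separate the two compounds on this read-out.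

Compound 3 `O=C(/C=C/c1cc2ccccc2[nH]c1=O)c1ccc(Cl)cc1` differs from compound 2 by chloro in place of hydroxy on an aromatic carbon, on an aromatic carbon of a six-membered aromatic ring of carbon only, para to a large group; cut one bond further out, the change reads 4-hydroxyphenyl to 4-chlorophenyl. Going by the values given here, no measured step covers this exchange. Among the compounds with values here, the only step, hydrogen in place of methyl on an oxygen on an aromatic ring, was a 1.4-fold lower number from compound 1 to compound 2 (0.14 log units; within the scatter) and within the scatter, so one change on this ring has already passed without a shift beyond the scatter. On that single precedent, no step beyond the scatter is expected in this assay for compound 3 in either direction; the expected step is a 1.0-fold higher number from compound 2 to compound 3 (0.01 log units; within the scatter). Compound 3 is therefore estimated at 2000 nM, with a range from 800 nM to 5000 nM.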

Compound 3, concentration for 50% growth inhibition: 3860 nM
Compound 3: middle estimate off by 1.9-fold (0.29 log units), on the low side; low and high end bracket the measured number.
By their numbers in this assay, from the lowest: compounds 2, 1 and 3 (each within the scatter of the next).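

In this assay, chloro in place of hydroxy on this aromatic carbon gives a 2.0-fold higher number from compound 2 to compound 3 (0.30 log units; within the scatter), and chloro in place of methoxy gives a 1.4-fold higher number from compound 1 to compound 3 (0.16 log units; within the scatter). The earlier pair differed only by a methyl on an oxygen, whereas compound 3 carries no oxygen on this carbon, and chloro brings no hydrogen-bond donor or acceptor, yet neither step separates it from compound 1 or compound 2 on this read-out. Across these three compounds, then, the read-out does not distinguish hydroxy, methoxy and chloro at this place, para to a large group, although three compounds are too few to call the position tolerant in general. Nothing available bears on why these three groups give values so close together.

The compounds shown leave open whether an amine, a carboxylic acid or a longer alkoxy chain at this place would produce a step beyond the scatter. They also leave open whether hydroxy, methoxy and chloro would stay unseparated if the same exchanges were read on a different cell line, or on a changed version of the shared core.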